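Phenol in place of styryl on the shared core

A few compounds are considered here, and "the series" means these few. Any claim that something is new, unique, unknown or untested is made for them only; others in the source may bear on it.

Of the compounds shown here, two of the shared core have been tested in a functional assay on the whole organism for inhibition, with Mus musculus as the target, in the writhing test, with a stated time of 15 min, at a dose of 10 mg/kg; a higher number here means more inhibition at the dose given (going by the name of the read-out), a lower number less inhibition. Compound 1 `O=C1N=C(C2C(=O)c3ccccc3C2=O)CC(c2ccccc2[N+](=O)[O-])N1` gives 35% in this assay. Within the data shown here, compound 2 `O=C1N=C(C2C(=O)c3ccccc3C2=O)CC(/C=C/c2ccccc2)N1` gives 16%, and in this assay compound 2 stands lowest of the two numbers; the only step to it is a number 19 percentage points lower from compound 1 to compound 2 (beyond the scatter), which is beyond the scatter.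

Compound 3 `O=C1N=C(C2C(=O)c3ccccc3C2=O)CC(c2ccccc2O)N1` is the next member. It differs from compound 2 in one place: 2-hydroxyphenyl in place of 2-phenylethenyl on a saturated ring carbon

Among the measured compounds shown here, only one measured step bears on this change, the step from compound 1 to compound 2, in which the 2-phenylethenyl group replaced 2-nitrophenyl and the number fell by a modest amount. Compound 3 undoes that exchange in kind, returning a six-membered aromatic ring of carbon only to the saturated ring carbon, now bearing a hydroxyl instead of a nitro group. On these data alone, because of a number 19 percentage points lower from compound 1 to compound 2 (beyond the scatter), an upward step of similar size is expected for compound 3, though the hydroxyl is untested here and the range is wide. Compound 3 is therefore estimated at 30% in this assay, between 12% and 50%, an expected step of a number 14 percentage points higher from compound 2 to compound 3 (beyond the scatter).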

Compound 3, a percentage reported as inhibition, in the whole organism at one dose (the size of the read-out at that dose, not a potency): 37%
For compound 3 the middle estimate is 7 percentage points below the measured one; low and high end bracket the measured number.
By their numbers in this assay, from the lowest: compound 2; then compounds 1 and 3 (each within the scatter of the next).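

In this assay, the 2-hydroxyphenyl group on the saturated ring carbon gives a number 21 percentage points higher from compound 2 to compound 3 (beyond the scatter), so the low number of compound 2 does not carry over to this group. The second reading, a number 2 percentage points higher from compound 1 to compound 3 (within the scatter), shows that hydroxy and nitro on the aromatic carbon cannot be told apart in this read-out, and compound 2, with its 2-phenylethenyl group, is the only one of the three whose steps to both others lie beyond the scatter. Nothing available here accounts for these differences.

On these data alone, what an amine or a methoxy group in place of the hydroxy would give remains open, as does the number for a plain phenyl group, which would show whether the substituent on the aromatic ring matters at all in this read-out. As far as these compounds go, each compound is also known at a single dose and only in this one test, so it remains open whether the low number of compound 2 and the matching numbers of compound 1 and compound 3 would hold at other doses.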